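The source may report more compounds than this note shows. Statements on the series, on what has been measured and on what is new or still open speak of the compounds shown alone.

Three compounds have been measured in an assay on isolated protein for inhibition of Alpha glucosidase (Homo sapiens), with stated times of 5 min and 15 min, tested at 50 uM; a higher number here means more inhibition at the concentration tested (going by the name of the read-out), a lower number less inhibition:

Compound 1, `O=C1/C(=C/c2ccccc2)CCC/C1=C\c1ccccc1Cl`, gives 43%.
Compound 2, `O=C(/C=C(O)/C=C/c1cccc(O)c1)c1cc(Cl)ccc1O`, gives 62.4%.
Compound 3, `O=C(/C=C(O)/C=C/c1ccc(O)c(O)c1)c1ccccc1O`, gives 93.6%.

Among these three numbers compound 1 stands lowest. The nearest to it is compound 2, whose value lies higher by a gap beyond the usual scatter, and the furthest is compound 3, whose value lies higher by a gap that is also beyond the scatter. Compounds 2 and 3 share a core that is different from that of compound 1, so their numbers say nothing about what a single change on the core of compound 1 does.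

The next compound, compound 4, `O=C1/C(=C/c2ccccc2)CCC/C1=C\c1cccc(Br)c1`, keeps the core of compound 1 and differs from it in one place only:

3-bromophenyl in place of 2-chlorophenyl on a double-bonded chain carbon bound to a double-bonded ring carbon

Within the data shown here, no pair of measured compounds differs in just one place, so there is no measured step to lean on for this change. A halogen-bearing phenyl ring is exchanged for another halogen-bearing phenyl ring, and nothing in the measured data shows that such an exchange moves the read-out. The step from compound 1 to compound 4 in this assay is therefore expected to be small, in either direction, and not beyond the scatter: a number 2 percentage points higher from compound 1 to compound 4 (within the scatter). Compound 4 is estimated at 45%, with a range from 25% to 65%.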

Compound 4, a percentage reported as inhibition, at one concentration (the size of the read-out at that concentration, not a potency): 27.2%
Estimate against measurement, compound 4: 17.8 percentage points above; the measured number falls inside the stated range.
By their numbers in this assay, from the lowest: compound 4; then compound 1; then compound 2; then compound 3.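

In this assay, placing 3-bromophenyl in place of 2-chlorophenyl on a double-bonded chain carbon bound to a double-bonded ring carbon gives a number 15.8 percentage points lower from compound 1 to compound 4 (beyond the scatter). Among these compounds, this is the first single-place comparison, and it shows that exchanging one halogen-bearing phenyl ring for another can move the read-out at this position, even though the two groups match in heavy-atom count, have no hydrogen-bond donors or acceptors, and carry no net charge. Nothing available on the properties of these two groups accounts for the drop in inhibition.

The exchange alters both the halogen, from chlorine to bromine, and its place on the phenyl ring, so this one step cannot show how much of the change belongs to each. The compounds shown also leave open whether a phenyl ring with no halogen at this position, or one carrying a different group such as an amine or a methoxy group, would raise or lower the number on the core of compound 1.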